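From tert-Butyl to Amino on a Shared Core

The source may hold more compounds than are shown below. What is called first, only, known or untested is meant among the compounds shown, and "the series" means these compounds.

In a functional assay (aorta) with Oryctolagus cuniculus as the target (a lower number here means tighter binding, a higher number weaker binding), compound 1 (`COc1cc(C(C)=O)ccc1OCCCN1CCC(C(c2ccc(F)cc2)c2ccc(F)cc2)CC1`) gives 1.59 nM and compound 2 (`COc1cc(C#N)ccc1OCCCN1CCC(C(c2ccc(F)cc2)c2ccc(F)cc2)CC1`) gives 2 nM while compound 3 (`CC(C)(C)c1ccc(OCCCN2CCC(C(c3ccc(F)cc3)c3ccc(F)cc3)CC2)cc1`) gives 1 nM so compound 3 stands level with the other two once the usual scatter of repeat measurements is allowed for.

The next structure is compound 4 (`Nc1ccc(OCCCN2CCC(C(c3ccc(F)cc3)c3ccc(F)cc3)CC2)cc1`) which carries amino in place of tert-butyl on an aromatic carbon, para to a large group (amino in place of tert-butyl on an aromatic carbon).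

Within the data shown here, no measured pair makes this exact exchange, and no compound measured so far carries amino, so the evidence is indirect. The nearest guides are the two steps that also replace the tert-butyl-bearing group: a 1.6-fold lower number from compound 1 to compound 3 (0.20 log units; within the scatter) and a 2.0-fold lower number from compound 2 to compound 3 (0.30 log units; within the scatter) for the whole substituted phenyl group. A further step, a 1.3-fold higher number from compound 1 to compound 2 (0.10 log units; within the scatter) when cyano takes the place of acetyl, is just as small. Among these three compounds, then, changes at this end of the molecule have stayed inside the scatter, and no change beyond the scatter is expected here, in either direction, though the uncertainty is wide.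

The expected step is a 1.8-fold higher number from compound 3 to compound 4 (0.26 log units; within the scatter) on this reading of the three compounds.

For compound 4 the estimated value is 1.8 nM with an expected range from 0.5 nM to 7 nM in this assay when it is measured.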

Compound 4, dissociation constant: 31.6 nM
Beside the measured number, compound 4's estimate is 18-fold (1.24 log units) below it; the measured number lies above the stated range.
By their numbers in this assay, from the lowest: compounds 3, 1 and 2 (each within the scatter of the next); then compound 4.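

In this assay, among these compounds, this position proves sensitive: a 32-fold higher number from compound 3 to compound 4 (1.50 log units; beyond the scatter) is the first step in the set to go beyond the scatter. Here tert-butyl, with 4 heavy atoms and 0 hydrogen-bond donors, gives way to amino, with 1 heavy atom, 1 hydrogen-bond donor and 1 hydrogen-bond acceptor, on the same aromatic carbon of an otherwise unchanged molecule. The other two steps are also large, a 16-fold higher number from compound 2 to compound 4 (1.20 log units; beyond the scatter) and a 20-fold higher number from compound 1 to compound 4 (1.30 log units; beyond the scatter), so the end of the molecule that looked free to vary among the first three compounds does not accept every group, and nothing in the data shown explains why this one behaves differently.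

The compounds shown leave open whether the step follows from losing tert-butyl or from gaining amino, as this single exchange changes both at once. A methyl group at the same place would show what happens with a small group that contains no nitrogen, and a dimethylamino group would show what happens when the nitrogen stays but its hydrogens are gone.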